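The source may report more compounds than this note shows. Statements on the series, on what has been measured and on what is new or still open speak of the compounds shown alone.

Compound 2 `CC(=O)c1c(NNc2ccc(Cl)cc2)cc(C)oc1=O` gives 58.6% in a functional assay on the whole organism for inhibition, with Rattus norvegicus as the target, read by paw edema, with a stated time of 3 h, at a dose of 50 mg/kg; on this read-out higher numbers stand for more inhibition at the one dose given (going by the name of the read-out) and lower numbers for less inhibition. Among the two compounds measured there it holds the lower of the two numbers, though its only neighbour, compound 1 `CC(=O)c1c(NNc2ccc(C)cc2)cc(C)oc1=O`, gives 59.6%, and the step of a number 1 percentage points lower from compound 1 to compound 2 (within the scatter) lies within the scatter, so the two cannot be told apart. Compound 3 `COc1ccc(NNc2cc(C)oc(=O)c2C(C)=O)cc1` has not yet been measured in this assay. It differs from compound 2 by methoxy in place of chloro on an aromatic carbon. Within the data shown here, the one measured step that bears on this change is the exchange at the same aromatic carbon of the six-membered ring, namely a number 1 percentage points lower from compound 1 to compound 2 (within the scatter), which did not move the number beyond the scatter. Among the measured compounds shown here, with only that single step as a guide, the exchange of one small group for another at this carbon is expected to leave the number about where it was, with no step beyond the scatter in either direction: the expected step is a number 0.4 percentage points higher from compound 2 to compound 3 (within the scatter). For compound 3 the estimated value in this assay is therefore 59%, with a range from 48% to 70%.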

Compound 3, a percentage reported as inhibition, in the whole organism at one dose (the size of the read-out at that dose, not a potency): 44.4%
Compound 3: the middle estimate sits 14.6 percentage points above what was measured; measured number below the stated range.
By their numbers in this assay, from the lowest: compound 3; then compounds 2 and 1 (each within the scatter of the next).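

In this assay, the aromatic carbon para to a large group proved sensitive to the group it carries, which the exchange of methyl and chloro alone had not shown: methoxy in place of chloro gives a number 14.2 percentage points lower from compound 2 to compound 3 (beyond the scatter), and methoxy in place of methyl gives a number 15.2 percentage points lower from compound 1 to compound 3 (beyond the scatter). Both steps lie beyond the scatter, so exchanges at this carbon cannot be taken as neutral in general, and methoxy stands apart from the two groups whose numbers could not be told apart. Nothing measured alongside these numbers speaks to why the methoxy compound differs, so the step stands as an observation only.

Methoxy differs from chloro both in bringing an oxygen and in having more heavy atoms, and the three compounds do not separate these two differences, so it remains open which of them, if either, goes with the lower number. On these data alone, a hydroxy or an ethoxy group at this carbon would bear on that question, an amine such as dimethylamino would show how a nitrogen there compares, and the effect of any of these at other doses or times also remains open.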